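The source may hold more compounds than are shown below. What is called first, only, known or untested is meant among the compounds shown, and "the series" means these compounds.

Compound 2 `O=C(Nc1cccc(/C=C/C(=O)c2nc3ccccc3[nH]2)c1)c1ccc(Cl)cc1` gives 7440 nM in a functional assay on 143B cells (Homo sapiens) for antiproliferative activity, read by MTT assay, with a stated time of 48 h (on this read-out higher numbers stand for weaker inhibition and lower numbers for stronger inhibition), the higher of the two numbers recorded so far; its nearest neighbour, compound 1 `O=C(Nc1cccc(/C=C/C(=O)c2nc3ccccc3[nH]2)c1)c1cccc(Cl)c1`, gives 3370 nM in this assay, and the step of a 2.2-fold higher number from compound 1 to compound 2 (0.34 log units; beyond the scatter) is the only measured one. Compound 3 `O=C(/C=C/c1cccc(NC(=O)c2ccccc2Br)c1)c1nc2ccccc2[nH]1` differs from compound 2 by 2-bromophenyl in place of 4-chlorophenyl on a carbonyl carbon. Among the measured compounds shown here, no measured step exchanges chlorine for bromine or reaches a 2-bromophenyl group, so that one step bears only loosely, showing that exchanging one chlorophenyl for another shifts the number modestly. Compound 3 is therefore expected to give 4500 nM in this assay, between 1800 nM and 11000 nM, an expected step of a 1.7-fold lower number from compound 2 to compound 3 (0.22 log units; within the scatter).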

Compound 3, half-maximal inhibitory concentration: 6050 nM
Estimate against measurement, compound 3: 1.3-fold (0.13 log units) below; the range from low to high includes it.
By their numbers in this assay, from the lowest: compounds 1, 3 and 2 (each within the scatter of the next, the first and the last beyond it).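

In this assay, the 2-bromophenyl group on the carbonyl carbon falls within the scatter of both chlorophenyl compounds (a 1.2-fold lower number from compound 2 to compound 3 (0.09 log units; within the scatter)) and (a 1.8-fold higher number from compound 1 to compound 3 (0.25 log units; within the scatter)). At this place, then, a change of halogen together with its ring position leaves compound 3 inseparable from either neighbour, and only the two chlorophenyl compounds stand apart from each other. No evidence given here bears on this result. From the compounds shown here alone, it remains open whether a different kind of group on this phenyl ring, such as an amine or a carboxylic acid, would move the number beyond the scatter.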